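Turning Compound 2 Into Its Mirror Image

The compounds below may be only part of what the source reports. "The series", "measured", "known", "first", "only" and "open" are said of these compounds alone.

Measured so far:
compound 1 `O=C(c1ccc(O)cc1O)[C@H]1[C@H](c2ccccc2)[C@@H](C(=O)c2ccc(O)cc2O)[C@@H]1c1ccccc1`: 12.8%
compound 2 `O=C(c1ccc(O)cc1O)[C@H]1Cc2ccccc2[C@@H](C(=O)c2ccc(O)cc2O)[C@H]1c1ccccc1`: 46.1%

In a functional assay on PC-3 cells (Homo sapiens) for cytotoxicity, read by MTT assay, with a stated time of 48 h, tested at 5 uM (a higher number here means a stronger effect of the compound at the concentration tested, a lower number a weaker effect), compound 1 gives 12.8%, while compound 2 gives 46.1%. Of the two numbers shown, compound 2 stands highest, and its gap to compound 1 is beyond the scatter, so the two truly differ. Compound 3 `O=C(c1ccc(O)cc1O)[C@@H]1Cc2ccccc2[C@H](C(=O)c2ccc(O)cc2O)[C@@H]1c1ccccc1` has not been measured. It differs from compound 2 only in configuration: the two compounds have the same atoms and bonds and differ only in configuration as drawn: 3 of 3 stereo elements differ (all stereocentres are inverted: mirror images); a stereocentre at a saturated ring carbon is drawn S in compound 2 and R in compound 3; a stereocentre at a saturated ring carbon is drawn S in compound 2 and R in compound 3; a stereocentre at a saturated ring carbon is drawn S in compound 2 and R in compound 3. Since every stereocentre is inverted, compound 3 is the mirror image of compound 2. Going by the values given here, nothing among the measured compounds shows how such an inversion moves the read-out, as no pair of mirror images has been measured. Without a guide, the expected step is a number 8.1 percentage points lower from compound 2 to compound 3 (within the scatter), not beyond the scatter, although a larger move in either direction cannot be ruled out. Compound 3 is therefore estimated at 38% in this assay, within a range from 12% to 60%.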

Compound 3, a percentage reported as activity, at one concentration (the size of the read-out at that concentration, not a potency): 22.3%
The estimate for compound 3 lay 15.7 percentage points above the measured number, within the range that was stated.
By their numbers in this assay, from the lowest: compounds 1 and 3 (each within the scatter of the next); then compound 2.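

Inverting every stereocentre matters in this assay: the change brings a number 23.8 percentage points lower from compound 2 to compound 3 (beyond the scatter). Going by these compounds alone, this is the first measured sign that the handedness of the shared core, and not just its atoms and their connections, can move this read-out. Handedness alone can account for the move, because no group enters or leaves: the fact that compounds 2 and 3 differ only in the configuration as drawn

All the stereocentres change together in this pair, so it cannot tell whether one of them matters most or whether inverting only one would produce a similar shift. It also leaves open whether the same preference for one mirror image would hold with an amine or a methoxy group in place of the hydroxyl groups, or at concentrations other than the one tested.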